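The source may hold more compounds than are shown below. What is called first, only, known or untested is meant among the compounds shown, and "the series" means these compounds.

Of the compounds shown here, three of the shared core have so far been read in an assay for inhibition of Rho-associated protein kinase 1 (Homo sapiens), read by TR-FRET, with stated times of 5 min and 2 h; a lower number here means a stronger inhibitor, a higher number a weaker inhibitor. Compound 1 `CC1(C)NC(=O)c2cc(-c3ccncc3)sc2N1` gives 100 nM in this assay. Compound 2 `Cc1n[nH]cc1-c1cc2c(s1)C(=O)N[C@]1(CC[C@@](O)(c3ccc(F)cc3)CC1)N2` gives 130 nM in this assay. Compound 3 `Cc1c(-c2cn[nH]c2)sc2c1N(C)C(C)(C)NC2=O` gives 44 nM in this assay, the lowest of the three numbers; its gaps to compound 1 and to compound 2 both lie beyond the scatter, so compound 3 is the strongest inhibitor of the set to date.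

Compound 4 `CN1c2cc(-c3cn[nH]c3)sc2C(=O)NC1(C)C` has not yet been measured. It differs from compound 3 in one place: hydrogen in place of methyl on an aromatic carbon. For the measured compounds named here, no pair of measured compounds isolates this change, so its size must be judged without a precedent in the set. Removing a single methyl from an aromatic carbon is expected to shift the number only modestly, if at all; the expected step from compound 3 to compound 4 in this assay is a 1.8-fold higher number from compound 3 to compound 4 (0.26 log units; within the scatter), toward a higher number and possibly not beyond the scatter. For compound 4 the estimate in this assay is 80 nM, with a range of 30 nM to 250 nM.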

Compound 4, half-maximal inhibitory concentration: 130 nM
For compound 4 the middle estimate is 1.6-fold (0.21 log units) below the measured one, and the stated range covers the measured number.
By their numbers in this assay, from the lowest: compound 3; then compounds 1, 2 and 4 (each within the scatter of the next).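

For the compounds shown here, the step of a 3.0-fold higher number from compound 3 to compound 4 (0.47 log units; beyond the scatter) in this assay is the first single change that can be read, and it shows that this aromatic carbon of the five-membered ring with sulfur is not silent. Here the methyl goes with the lower number, and a change of one heavy atom, with no hydrogen-bond donor or acceptor involved, is enough to give a step beyond the scatter. Nothing shown explains why this methyl matters.

The compounds shown hold only hydrogen or methyl on this carbon, so it remains open whether an ethyl, a chlorine or a methoxy group there would give a lower or a higher number than methyl. The step also rests on one pair carrying a 1H-pyrazol-4-yl group, and whether it holds with another group in that place is open.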